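A few compounds are considered here, and "the series" means these few. Any claim that something is new, unique, unknown or untested is made for them only; others in the source may bear on it.

In an ADME assay on Vero cells (Chlorocebus sabaeus) for cytotoxicity, read by colorimetric assay, with a stated time of 3 days (on this read-out lower numbers stand for stronger inhibition and higher numbers for weaker inhibition), compound 1 (`Cc1cccc(Sc2c([N+](=O)[O-])cc(C(F)(F)F)cc2[N+](=O)[O-])c1`) gives 7300 nM and compound 2 (`O=[N+]([O-])c1cc(C(F)(F)F)cc([N+](=O)[O-])c1Sc1ccc(Cl)cc1Cl`) gives 4300 nM on the same scale. These two numbers are all that exists so far, and they lie within the scatter of each other, so compound 2 has no place apart from compound 1. The open case is compound 3 (`COc1ccc(Sc2c([N+](=O)[O-])cc(C(F)(F)F)cc2[N+](=O)[O-])cc1`), with 4-methoxyphenyl in place of 2,4-dichlorophenyl on a sulfur. Going by the values given here, the one measured step that bears on this is (a 1.7-fold lower number from compound 1 to compound 2 (0.23 log units; within the scatter)), also a change of the group on that sulfur, and it stays within the scatter. Among the compounds with values here, with that as the only guide, no step beyond the scatter is expected in this assay for this change, though a single step is thin evidence. The expected step is (a 1.3-fold higher number from compound 2 to compound 3 (0.11 log units; within the scatter)) as an estimate. Compound 3 is estimated at 5500 nM with an expected range from 2200 nM to 14000 nM in this read-out.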

Compound 3, half-maximal inhibitory concentration: 12000 nM
Compound 3: middle estimate off by 2.2-fold (0.34 log units), on the low side, within the range that was stated.
By their numbers in this assay, from the lowest: compounds 2, 1 and 3 (each within the scatter of the next, the first and the last beyond it).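

In this assay, going by these compounds alone, the group on this sulfur can move the number beyond the scatter: 4-methoxyphenyl in place of 2,4-dichlorophenyl gives (a 2.8-fold higher number from compound 2 to compound 3 (0.45 log units; beyond the scatter)), the only step in the set that goes beyond it, and only modestly. 4-methoxyphenyl in place of 3-methylphenyl gives (a 1.6-fold higher number from compound 1 to compound 3 (0.22 log units; within the scatter)), which stays within the scatter, so only compound 2 and compound 3 stand apart and compound 1 separates from neither. No measurement on hand accounts for the step between compound 2 and compound 3.

On these data alone, how much of that step belongs to the two chlorines and how much to the methoxy group stays open. Also open, as far as these compounds go, is how the number responds on this sulfur to an amine, a carboxylic acid or a longer alkyl chain in place of the aryl group.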